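Swapping an Ethylphenyl Arm for a Thiazole Ring

This account rests on a few compounds, and the source may have more. Where it says the series, first, only, none or still open, it means among the compounds named here.

This set comes from a series of compounds built around one shared core, carrying a doubly unsaturated side chain that ends in an aromatic ring. Compound 1 `COC1=C(C)C(=O)/C(=C(O)/C=C/c2ccc(F)cc2)C(=O)C1(C)C` belongs to the set, but in a functional assay on 1A9 cells (Homo sapiens) for cytotoxicity (on this read-out lower numbers stand for an effect already at smaller amounts and higher numbers for an effect only at larger amounts of compound), compound 1 gives "not determined" (no result reported), so it offers no number. Going by the values given here, compound 2 `CCc1ccc(/C=C/C(O)=C2/C(=O)C(C)=C(OC)C(C)(C)C2=O)cc1` is the only member with a number: in this assay compound 2 gives 5.3 ug/mL, and with nothing else measured there is no second value against which it can be placed.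

Compound 3 `COC1=C(C)C(=O)/C(=C(O)/C=C/c2nccs2)C(=O)C1(C)C` carries the same core and the same unsaturated chain, but differs at the end of that chain: 1,3-thiazol-2-yl in place of 4-ethylphenyl on a double-bonded chain carbon bound to a double-bonded chain carbon. Among the compounds with values here, no measured pair in this set shows what such a change does, so the expectation rests on compound 2 alone. A smaller aromatic ring with two hetero atoms replaces a larger carbon-only ring, and a modest loss of potency in this assay is expected, with the step from compound 2 to compound 3 estimated at a 1.9-fold higher number from compound 2 to compound 3 (0.28 log units; within the scatter). Compound 3 is therefore estimated at 10 ug/mL in this assay, within a range from 3 ug/mL to 35 ug/mL.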

Compound 3, concentration for half-maximal effect: 3.5 ug/mL
Beside the measured number, compound 3's estimate is 2.9-fold (0.46 log units) above it; the range from low to high includes it.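

Going by these compounds alone, compound 2 alone could give only a single number, but with compound 3 there is now a real comparison at the end of the chain. In this assay the swap of 4-ethylphenyl for 1,3-thiazol-2-yl gives (a 1.5-fold lower number from compound 2 to compound 3 (0.18 log units; within the scatter)), so this pair cannot be told apart on this read-out, even though a five-membered aromatic ring with 2 hetero atoms has replaced a six-membered aromatic ring of carbon only. For this one pair, then, the position on a double-bonded chain carbon bound to a double-bonded chain carbon accepts a quite different aromatic ring with no change beyond the usual scatter, and nothing available explains why.

Steps involving compound 1 cannot be read, so the 4-fluorophenyl end adds nothing to this comparison. From the compounds shown here alone, it also remains open whether the same holds for end groups of another kind, such as a pyridine ring, a carboxylic acid or an amine on a longer chain, and one pair cannot show whether the result extends beyond these two compounds.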